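The source may report more compounds than this note shows. Statements on the series, on what has been measured and on what is new or still open speak of the compounds shown alone.

Of the compounds shown here, two have so far been tested in an assay for inhibition of steroid 17-alpha-hydroxylase/17,20 lyase (Homo sapiens), using NADPH, tested at 0.2 uM; on this read-out lower numbers stand for a weaker effect and higher numbers for a stronger effect at the one concentration tested. Compound 1 `c1cn(Cc2ccc(-c3ccoc3)cc2)cn1` gives 3% in this assay. Compound 2 `ClCc1ccc(-c2ccc(Cn3ccnc3)cc2)cn1` gives 9% in this assay, the higher of the two numbers, but the gap to compound 1 stays within the usual scatter of repeated measurements, so the two readings are best taken as alike: each shows only a small effect at the single concentration tested. Compound 3 `c1cncc(-c2ccc(Cn3ccnc3)cc2)c1` has not yet been measured. It differs from compound 2 in one place: hydrogen in place of chloromethyl on an aromatic carbon. Among the measured compounds shown here, no measured pair shows a change of this kind, so the expectation leans on compound 2 giving 9% and compound 1 giving 3%, both small effects. The expected step is a number 3 percentage points lower from compound 2 to compound 3 (within the scatter), nothing beyond the scatter. Compound 3 is therefore estimated to give 6% in this assay, within a range of 0% to 16%.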

Compound 3, a percentage reported as inhibition, at one concentration (the size of the read-out at that concentration, not a potency): 2%
Compound 3: middle estimate off by 4 percentage points, on the high side, within the range that was stated.
By their numbers in this assay, from the lowest: compounds 3, 1 and 2 (each within the scatter of the next).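

Putting hydrogen in place of chloromethyl, on the aromatic carbon next to the ring nitrogen and para to a large group, shows no effect beyond the scatter in this assay (a number 7 percentage points lower from compound 2 to compound 3 (within the scatter)). Putting pyridin-3-yl in place of furan-3-yl on the same core also stays within the scatter (a number 1 percentage points lower from compound 1 to compound 3 (within the scatter)). Neither the chloromethyl group nor the swap between these two rings therefore makes a measurable difference at this single concentration, and no other measurement here bears on this result.

As far as these compounds go, it remains open whether another group on that aromatic carbon, such as an amine or a carboxylic acid, would give a clearly larger reading. With all three readings this small, a further drop would also be hard to detect at this concentration.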